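The source may report more compounds than this note shows. Statements on the series, on what has been measured and on what is new or still open speak of the compounds shown alone.

Compound 2 `CCCCCOC(=O)c1cccc(-c2cc(C(=O)Nc3ccncc3)ccc2CN)c1` and compound 1 `CCCOC(=O)c1cccc(-c2cc(C(=O)Nc3ccncc3F)ccc2CN)c1` share the same core and differ from each other in two places. In an assay on isolated protein for inhibition of Rho-associated protein kinase 2 (Homo sapiens), read by radiometric assay (on this read-out higher numbers stand for weaker inhibition and lower numbers for stronger inhibition), compound 2 gives 4.9 nM, and compound 1 gives 5.1 nM, so the two numbers lie within the usual scatter of each other. Compound 3 `CCCOC(=O)c1cccc(-c2cc(C(=O)Nc3ccncc3)ccc2CN)c1` is reached from compound 2 by hydrogen in place of ethyl on a saturated chain carbon, three bonds along the chain from an oxygen next to a carbonyl group. Going by the values given here, no measured pair isolates this single change, so the step is expected to stay within the scatter and in no clear direction, a 1.0-fold higher number from compound 2 to compound 3 (0.01 log units; within the scatter). Compound 3 is therefore estimated at 5 nM, with a likely range from 2 nM to 12 nM.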

Compound 3, half-maximal inhibitory concentration: 1.4 nM
For compound 3 the middle estimate is 3.6-fold (0.55 log units) above the measured one, outside the stated range (below it).
By their numbers in this assay, from the lowest: compound 3; then compounds 2 and 1 (each within the scatter of the next).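

Going from pentyl to propyl on the chain strengthens inhibition in this assay (a 3.5-fold lower number from compound 2 to compound 3 (0.54 log units; beyond the scatter)). Hydrogen in place of fluoro on an aromatic carbon also strengthens it (a 3.6-fold lower number from compound 1 to compound 3 (0.56 log units; beyond the scatter)), so each of these two places matters on its own, and the close values of compound 1 and compound 2 concealed two separate effects. No measurement here explains why either change acts this way.

Still open, on these data alone, is whether a shorter chain, such as ethyl or methyl, strengthens inhibition further, and whether chloro on that aromatic carbon behaves like fluoro.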